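This account rests on a few compounds, and the source may have more. Where it says the series, first, only, none or still open, it means among the compounds named here.

Measured so far in a functional assay on A549 cells (Homo sapiens) for antiproliferative activity, read by MTT assay, with a stated time of 72 h; on this read-out lower numbers stand for stronger inhibition and higher numbers for weaker inhibition:
Compound 1 `CCCCCc1ccc(-c2cn(C[C@H](O)[C@H]3OC(=O)C(OCc4ccccc4)=C3OCc3ccccc3)nn2)cc1` gives 6220 nM.
Compound 2 `O=C1O[C@H]([C@@H](O)Cn2cc(CNS(=O)(=O)c3ccc(F)cc3)nn2)C(OCc2ccccc2)=C1OCc1ccccc1` gives 22500 nM.
Compound 3 `CCCCCCCCCCc1cn(C[C@H](O)[C@H]2OC(=O)C(OCc3ccccc3)=C2OCc2ccccc2)nn1` gives 6750 nM.

Compound 3 stands second highest of these three numbers. Its nearest neighbour is compound 1, where the step of a 1.1-fold higher number from compound 1 to compound 3 (0.04 log units; within the scatter) lies within the scatter; its furthest is compound 2, with a step of a 3.3-fold lower number from compound 2 to compound 3 (0.52 log units; beyond the scatter). Compound 4 `Cc1ccc(-c2cn(C[C@H](O)[C@H]3OC(=O)C(OCc4ccccc4)=C3OCc3ccccc3)nn2)cc1` differs from compound 3 by 4-methylphenyl in place of decyl on an aromatic carbon. For the measured compounds named here, the one measured step that bears on this is a 1.1-fold higher number from compound 1 to compound 3 (0.04 log units; within the scatter), where exchanging a chain for a 4-pentylphenyl group left the number essentially unchanged; 4-methylphenyl is a close relative of that group. Compound 4 is therefore expected to show a 1.1-fold higher number from compound 3 to compound 4 (0.05 log units; within the scatter), no step beyond the scatter. Compound 4 is estimated at 7500 nM, with a range from 3000 nM to 18000 nM.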

Compound 4, half-maximal inhibitory concentration: 8690 nM
Estimate against measurement, compound 4: 1.2-fold (0.06 log units) below; the measured number falls inside the stated range.
By their numbers in this assay, from the lowest: compounds 1, 3 and 4 (each within the scatter of the next); then compound 2.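

At this aromatic carbon, in this assay, 4-methylphenyl and decyl cannot be told apart, with a 1.3-fold higher number from compound 3 to compound 4 (0.11 log units; within the scatter), and shortening the chain on the phenyl from pentyl to methyl also leaves no readable difference, with a 1.4-fold higher number from compound 1 to compound 4 (0.15 log units; within the scatter). The separation from the sulfonylamino compound persists with this much smaller aryl group, at a 2.6-fold lower number from compound 2 to compound 4 (0.41 log units; beyond the scatter), so neither the length of the chain nor the presence of the phenyl ring separates compounds 1, 3 and 4, and only compound 2 stands apart. No measurement at hand accounts for these steps.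

Still open, as far as these compounds go, is whether an amine or a carboxylic acid on the phenyl ring, or a chain longer than decyl, would move the number beyond the scatter.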